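From a Hydroxy Group to a Larger Substituent on Compound 1

This account rests on a few compounds, and the source may have more. Where it says the series, first, only, none or still open, it means among the compounds named here.

Compound 1 `C/C(=N\O)c1ccc2[nH]c(-c3ccccc3)nc2c1`: in an ADME assay on Vero cells (Chlorocebus sabaeus) for cytotoxicity, read by MTT assay, with a stated time of 96 h (a lower number here means that less compound is tolerated, a higher number that more compound is tolerated), compound 1 gives only a limit, > 100000 nM.
Compound 2 `C/C(=N\O)c1ccc2[nH]c(-c3ccc(Cl)cc3)nc2c1`: in this assay compound 2 gives "not determined" (no result reported).
Compound 3 `C/C(=N\O)c1ccc2[nH]c(-c3ccc(C(F)(F)F)cc3)nc2c1`: in this assay compound 3 gives "not determined" (no result reported).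

Compound 1 stands at the edge of what the assay resolves: its result is a limit rather than a number (the limit of > 100000 nM in this assay, at which 1 of the 3 values shown sits). Within the data shown here, compounds 2 and 3 bring no number at all, so no comparison between measured compounds is possible here. Compound 4 `C/C(=N\NC(N)=S)c1ccc2[nH]c(-c3ccccc3)nc2c1` differs from compound 1 by a group of 4 heavy atoms (1 carbon, 2 nitrogen, 1 sulfur; no ring) in place of one oxygen atom, on a double-bonded nitrogen. No measured step connects any pair of these compounds, so no direction can be drawn from them. Compound 4 is expected to sit near compound 1, with a number no higher from compound 1 to compound 4 (the limit leaves the size open) meaning no step beyond the scatter. Compound 4 is estimated at 100000 nM, between 30000 nM and 300000 nM, and a limit may well be reported again.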

Compound 4, half-maximal cytotoxic concentration: > 100000 nM
Compound 4: no number, only a limit; the forecaster's own chance of this, stated with the estimate: 60%; the middle value lies on the limit itself.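

Among these compounds, compound 1 and compound 4 each give only a limit in this assay, so no step between them can be read: the limit of > 100000 nM in this assay, at which 2 of the 4 values shown sit. The compounds shown leave open whether the hydroxy group and the larger group replacing it differ at all in this assay.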